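Ether change on the shared core: outlook for compound 4

The source may hold more compounds than are shown below. What is called first, only, known or untested is meant among the compounds shown, and "the series" means these compounds.

Measured so far in a functional assay on RKO cells (Homo sapiens) for cytotoxicity, read by MTT assay, with a stated time of 48 h; a higher number here means a weaker inhibitor, a lower number a stronger inhibitor:
- compound 1 `CCOc1ccc2c(NCCCN(C)C)ccnc2c1` gives 5240 nM
- compound 2 `CCOc1ccc2c(Cl)ccnc2c1` gives 3870 nM
- compound 3 `CN(C)CCNc1ccnc2cc(OCc3ccc(F)cc3)ccc12` gives 580 nM

Compound 3 stands lowest of the three numbers in this assay; its gaps to compound 2 and to compound 1 both lie beyond the scatter, so it is the strongest inhibitor of the set. Compound 1 and compound 2 sit close to one another at the weak end.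

Compound 4 `CCOc1ccc2c(NCCN(C)C)ccnc2c1` has not been measured. It differs from compound 3 as follows: methyl in place of 4-fluorophenyl on a saturated chain carbon bound to an oxygen on an aromatic ring. Seen one bond further out, a 4-fluorobenzyl becomes an ethyl, which brings the ether of compound 4 to the same ethyl ether carried by compound 1 and compound 2, the two weaker compounds. On that basis a step upward in this assay, beyond the scatter, is expected from compound 3 to compound 4, estimated at a 6.9-fold higher number from compound 3 to compound 4 (0.84 log units; beyond the scatter). Compound 4 is expected to give about 4000 nM, in the range 1500 nM to 12000 nM, because compound 1 gives 5240 nM.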

Compound 4, half-maximal inhibitory concentration: 3650 nM
Beside the measured number, compound 4's estimate is 1.1-fold (0.04 log units) above it, and the stated range covers the measured number.
By their numbers in this assay, from the lowest: compound 3; then compounds 4, 2 and 1 (each within the scatter of the next).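

In this assay, for the compounds shown here, the change from 4-fluorobenzyl to ethyl with the (2-(dimethylamino)ethyl)amino group held constant gives a 6.3-fold higher number from compound 3 to compound 4 (0.80 log units; beyond the scatter), the first single-place reading at the ether, and it lies beyond the scatter. On the ethyl ether, the other two changes stay within the scatter: chloro to (2-(dimethylamino)ethyl)amino gives a 1.1-fold lower number from compound 2 to compound 4 (0.03 log units; within the scatter), and (dimethylamino)methyl to dimethylamino on the chain gives a 1.4-fold lower number from compound 1 to compound 4 (0.16 log units; within the scatter). No measurement shown here accounts for the step at the ether.

Still open, as far as these compounds go, is whether the step follows the fluorine or the aromatic ring, which an unsubstituted benzyl ether and a longer alkyl ether such as butyl would help separate. Also open, from the compounds shown here alone, is whether the group on the aromatic carbon stays without a step beyond the scatter on the 4-fluorobenzyl ether, which chloro or (3-(dimethylamino)propyl)amino there would test.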